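A few compounds are considered here, and "the series" means these few. Any claim that something is new, unique, unknown or untested is made for them only; others in the source may bear on it.

Measured so far in a functional assay on the whole organism with Mus musculus as the target, in the maximal electroshock model, with a stated time of 1 h; on this read-out lower numbers stand for an effect already at smaller amounts and higher numbers for an effect only at larger amounts of compound:
compound 1 `Cc1ccccc1-c1nnc(N(C)N)s1` gives 75 mg/kg
compound 2 `Cc1ccccc1-c1nnc(N(N)C(C)C)s1` gives 54 mg/kg
compound 3 `Cc1ccccc1-c1nnc(N(N)c2ccccc2)s1` sits at a limit of the assay, > 100 mg/kg

For the measured compounds named here, compound 1 has the highest of the two numbers; the nearest is the one from compound 2, and a 1.4-fold lower number from compound 1 to compound 2 (0.14 log units; within the scatter) lies within the scatter. The step from compound 1 to compound 3 ends at a limit (the limit of > 100 mg/kg in this assay, at which 1 of the 3 values shown sits), as does the step from compound 2 to compound 3.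

Compound 4 `Cc1ccccc1-c1nnc(N(C)NC2CCCC2)s1` differs from compound 1 in one place: cyclopentyl in place of hydrogen on an amine nitrogen. Going by the values given here, none of the measured steps touches that amine nitrogen; they all change the group on the nitrogen on the aromatic ring, where isopropyl in place of methyl gave a 1.4-fold lower number from compound 1 to compound 2 (0.14 log units; within the scatter). An alkyl group added to compound 1 is therefore expected to leave this assay roughly unchanged, so a 1.1-fold lower number from compound 1 to compound 4 (0.03 log units; within the scatter) is the estimated step, and compound 4 is expected to give about 70 mg/kg, between 35 mg/kg and 140 mg/kg.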

Compound 4, dose for half-maximal effect: 110 mg/kg
Compound 4: the middle estimate sits 1.6-fold (0.20 log units) below what was measured; the measured number falls inside the stated range.
By their numbers in this assay, from the lowest: compounds 2, 1 and 4 (each within the scatter of the next, the first and the last beyond it).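

The first change shown on the amine nitrogen, cyclopentyl in place of hydrogen, gives a 1.5-fold higher number from compound 1 to compound 4 (0.17 log units; within the scatter). In this assay, then, a ring this size can sit on that nitrogen while the numbers of the two compounds stay indistinguishable. Nothing measured here bears on this step.

From the compounds shown here alone, what a longer chain or a carboxylic acid on this amine nitrogen would do remains open. So does whether cyclopentyl would behave the same way with isopropyl or phenyl on the neighbouring nitrogen of the core.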